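From Trifluoromethyl to 4-(Trifluoromethyl)phenoxy in Compound 2

This account rests on a few compounds, and the source may have more. Where it says the series, first, only, none or still open, it means among the compounds named here.

Measured so far in a functional assay with Homo sapiens as the target; a higher number here means a weaker inhibitor, a lower number a stronger inhibitor:
Compound 1 `CC(C)[C@H](NC(=O)COc1cccc2ccccc12)C(=O)N[C@@H](CC(=O)O)C(=O)COC(=O)c1c(Cl)cccc1Cl`: 11500 nM
Compound 2 `CC(C)[C@H](NC(=O)COc1cccc2ccccc12)C(=O)N[C@@H](CC(=O)O)C(=O)COc1ccc(C(F)(F)F)cc1`: 12300 nM

Among the compounds with values here, compound 2 cannot be told apart from the only other measured compound. Within the data shown here, the single measured step, a swap of the whole group on the oxygen, is a 1.1-fold higher number from compound 1 to compound 2 (0.03 log units; within the scatter). Compound 3 `CC(C)[C@H](NC(=O)COc1cccc2ccccc12)C(=O)N[C@@H](CC(=O)O)C(=O)COc1ccc(Oc2ccc(C(F)(F)F)cc2)cc1` differs from compound 2 in one place, on an aromatic carbon of a six-membered aromatic ring of carbon only, para to a large group: 4-(trifluoromethyl)phenoxy in place of trifluoromethyl on an aromatic carbon. That is 4-(trifluoromethyl)phenoxy in place of trifluoromethyl, a different change from the swap already measured. The measured step is therefore only a weak guide, but it offers no sign of a large shift. In this assay, no step beyond the scatter is expected in either direction. The expected step is a 1.2-fold lower number from compound 2 to compound 3 (0.09 log units; within the scatter). One step is thin evidence, so the range stays wide. For compound 3 the estimate is 10000 nM, with an expected range of 3000 nM to 30000 nM.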

Compound 3, half-maximal inhibitory concentration: 24900 nM
Beside the measured number, compound 3's estimate is 2.5-fold (0.40 log units) below it; the range from low to high includes it.
By their numbers in this assay, from the lowest: compounds 1 and 2 (each within the scatter of the next); then compound 3.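

Extending the group on this aromatic carbon matters in this assay: 4-(trifluoromethyl)phenoxy in place of trifluoromethyl, which adds a six-membered aromatic ring and a hydrogen-bond acceptor, gives a 2.0-fold higher number from compound 2 to compound 3 (0.31 log units; beyond the scatter) and so a modestly weaker inhibitor. The earlier swap on the oxygen, a 1.1-fold higher number from compound 1 to compound 2 (0.03 log units; within the scatter), separated nothing, so this is the first change shown to move the number beyond the scatter, and the larger group does not help here. Nothing measured here explains the rise.

Still open, from the compounds shown here alone, is whether the rise follows from the added ring or from the oxygen that links it, which a plain phenyl or a methoxy group at this carbon could help to separate. Also open, going by these compounds, is how an amine or a carboxylic acid at this carbon would change the number.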